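Open-chain diamine replacing the piperazine of compound 2

The compounds below may be only part of what the source reports. "The series", "measured", "known", "first", "only" and "open" are said of these compounds alone.

Three compounds of the series have numbers in a physicochemical assay for acid dissociation. Compound 1 `CO[C@@H]1[C@@H](OC(=O)c2ccc(C)[nH]2)[C@@H](O)[C@H](Oc2ccc3c(N4CCNCC4)cc(=O)oc3c2C)OC1(C)C` gives 8.3. Compound 2 `CO[C@@H]1[C@@H](OC(=O)c2ccc(C)[nH]2)[C@@H](O)[C@H](Oc2ccc3c(N4CCNC(C)C4)cc(=O)oc3c2C)OC1(C)C` gives 8.3 and so stands level with compound 1 at the digits shown, the two together the highest of the three; the step of no change at the digits printed from compound 1 to compound 2 (within the scatter) is within the scatter. Compound 3 `CO[C@@H]1[C@@H](OC(=O)c2ccc(C)[nH]2)[C@@H](O)[C@H](Oc2ccc3c(N4CCN(C)CC4)cc(=O)oc3c2C)OC1(C)C` gives 7.3, and the steps of a number 1.00 log units lower from compound 1 to compound 3 (beyond the scatter) and a number 1.00 log units lower from compound 2 to compound 3 (beyond the scatter) are both beyond the scatter.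

Compound 4 `CO[C@@H]1[C@@H](OC(=O)c2ccc(C)[nH]2)[C@@H](O)[C@H](Oc2ccc3c(N(C)CCN(C)C)cc(=O)oc3c2C)OC1(C)C` has not been measured. It differs from compound 2 in one place: (2-(dimethylamino)ethyl)(methyl)amino in place of 3-methylpiperazin-1-yl on an aromatic carbon. The group that enters has 0 hydrogen-bond donors, so, as in compound 3, no amine hydrogen remains in the side group. The step that bears most directly on this is a number 1.00 log units lower from compound 1 to compound 3 (beyond the scatter), which turned a ring amine hydrogen into a methyl, with the same reading in a number 1.00 log units lower from compound 2 to compound 3 (beyond the scatter). A change of the same kind and about the same size, downward, is therefore expected here, the open chain making the exact size uncertain.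

For compound 4 the expected value in this assay is 7.5, between 6.9 and 8.1, which means an expected step of a number 0.80 log units lower from compound 2 to compound 4 (beyond the scatter).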

Compound 4, acid dissociation constant: 8.2
Beside the measured number, compound 4's estimate is 0.70 log units below it, and the stated range ends below it.
By their numbers in this assay, from the lowest: compound 3; then compounds 4, 1 and 2 (each within the scatter of the next).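

In this assay the open chain (2-(dimethylamino)ethyl)(methyl)amino, with 0 hydrogen-bond donors, gives a number 0.10 log units lower from compound 2 to compound 4 (within the scatter) and a number 0.10 log units lower from compound 1 to compound 4 (within the scatter), which places it with the two compounds that keep an amine hydrogen in the side group. Compound 3 also has 0 hydrogen-bond donors in that group, yet the chain gives a number 0.90 log units higher from compound 3 to compound 4 (beyond the scatter), so the donor count alone does not sort these four compounds, and the earlier step of a number 1.00 log units lower from compound 1 to compound 3 (beyond the scatter) cannot be read as the effect of losing the amine hydrogen at this position on the aromatic carbon opposite the ring oxygen. Nothing available gives a reason for the difference between the 4-methylpiperazin-1-yl ring and the open chain.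

These compounds do not show which of the two nitrogens in each side group gives the reading in this assay. Also open, going by these compounds, is whether the level of compound 4 would hold with a longer chain between the two nitrogens, or with a pyrrolidine or a primary amine in place of the terminal dimethylamino group.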